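The source may report more compounds than this note shows. Statements on the series, on what has been measured and on what is new or still open speak of the compounds shown alone.

The measured compounds:

Compound 1, `CN(C)Cc1ccc2nc(NC(=O)N/N=C/c3cn(Cc4ccccc4Cl)c4ccccc34)sc2c1`, gives 1600 nM in a functional assay on NCI-H460 cells (Homo sapiens) for cytotoxicity, read by MTT assay, with a stated time of 72 h; on this read-out higher numbers stand for weaker inhibition and lower numbers for stronger inhibition.
Compound 2, `Cc1ccc(Cn2cc(/C=N/NC(=O)Nc3nc4ccc(CN5CCC(C)CC5)cc4s3)c3ccccc32)cc1`, gives 410 nM in this assay.
Compound 3, `Cc1ccc(Cn2cc(/C=N/NC(=O)Nc3nc4ccc(CN(C)C)cc4s3)c3ccccc32)cc1`, gives 200 nM in this assay.

Compound 4, `CC1CCN(Cc2ccc3nc(NC(=O)N/N=C/c4cn(Cc5ccccc5Cl)c5ccccc45)sc3c2)CC1`, has not yet been measured in this assay.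

All four compounds share one scaffold and differ at two ends. The two cores differ as described by 4-methylpiperidin-1-yl in place of dimethylamino on a saturated chain carbon bound to an aromatic carbon; this change is seen once among the measured compounds, where it gave a 2.1-fold lower number from compound 2 to compound 3 (0.31 log units; beyond the scatter).

The change that leads to compound 4 is the other one. Among the compounds shown it occurs two times. Once it is already measured: from compound 3 to compound 1, (2-chlorophenyl in place of 4-methylphenyl on a saturated chain carbon bound to an aromatic nitrogen), it gave an 8.0-fold higher number from compound 3 to compound 1 (0.90 log units; beyond the scatter). The second time it is applied to compound 2 to give compound 4, (2-chlorophenyl in place of 4-methylphenyl on a saturated chain carbon bound to an aromatic nitrogen). The two place lines read the same word for word, so the change sits on the same kind of position both times.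

Going by the values given here, with only one measured example of this change, the expectation for compound 4 rests on that single step. Compound 4 is therefore expected to show a weakening of about the same size as the measured one, that is a 6.8-fold higher number from compound 2 to compound 4 (0.83 log units; beyond the scatter) in this assay, because compound 1 gave an 8.0-fold higher number from compound 3 to compound 1 (0.90 log units; beyond the scatter) relative to compound 3. The estimate for compound 4 in this assay is 2800 nM, with a range from 1000 nM to 7500 nM.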

Compound 4, half-maximal inhibitory concentration: 1080 nM
Compound 4: the middle estimate sits 2.6-fold (0.41 log units) above what was measured; low and high end bracket the measured number.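

In this assay, 2-chlorophenyl in place of 4-methylphenyl again gives weaker inhibition, with a 2.6-fold higher number from compound 2 to compound 4 (0.42 log units; beyond the scatter), so the direction of this change carries over from one core to the other, but its size does not: the same change on two cores in this assay, an 8.0-fold higher number (0.90 log units; beyond the scatter) from compound 3 to compound 1 and a 2.6-fold higher number (0.42 log units; beyond the scatter) from compound 2 to compound 4, 3.0-fold (0.48 log units) apart, beyond the scatter of two such steps

The amine at the other end of the molecule behaves in a similar way: with the 2-chlorobenzyl group in place, the exchange of dimethylamino for 4-methylpiperidin-1-yl gives a 1.5-fold lower number from compound 1 to compound 4 (0.17 log units; within the scatter), so this step does not reproduce the one seen with the 4-methylbenzyl group: the same change on two cores in this assay, a 2.1-fold lower number (0.31 log units; beyond the scatter) from compound 2 to compound 3 and a 1.5-fold higher number (0.17 log units; within the scatter) from compound 4 to compound 1, 3.0-fold (0.48 log units) apart, beyond the scatter of two such steps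

Together, these two comparisons show that the effect of a change at one end of these molecules depends on what sits at the other end, so a step measured on one core gives its likely direction at best, not a reliable size, yet with only four compounds they do not show why the steps differ or how far this holds across the wider series.

The compounds shown leave open whether the weakening follows the chlorine itself or the place it occupies on the ring, a question that a 4-chlorobenzyl or a 2-methylbenzyl group could help to settle. They also leave open how either benzyl group would pair with a different amine, such as morpholin-4-yl.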